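The source may report more compounds than this note shows. Statements on the series, on what has been measured and on what is new or still open speak of the compounds shown alone.

Measured compounds in the series:

Compound 1, `CCCNc1nc(N)nc2c1ncn2/C=C1/CC1(CO)CO` — > 24000 nM, a limit of the assay.
Compound 2, `CCCOc1nc(N)nc2c1ncn2/C=C1/CC1(CO)CO` — > 20000 nM, a limit of the assay.
Compound 3, `CCCCCCSc1nc(N)nc2c1ncn2/C=C1/CC1(CO)CO` — > 20000 nM, a limit of the assay.

In an ADME assay on Akata cells (Homo sapiens) for cytotoxicity, with a stated time of 7 days (on this read-out lower numbers stand for higher toxicity in this test and higher numbers for lower toxicity in this test), compound 3 gives > 20000 nM, which is a limit and not a number. The two other values are likewise limits, so all three compounds stand together at the edge of the tested range and none is separated from another. The steps that reach compound 3, a step that the two limits leave unreadable from compound 1 to compound 3 and a step that the two limits leave unreadable from compound 2 to compound 3, are therefore unreadable in size, as is a step that the two limits leave unreadable from compound 1 to compound 2. What can be said is that the limit of > 20000 nM in this assay, at which 2 of the 3 values shown sit, and the limit of > 24000 nM in this assay, at which 1 of the 3 values shown sits, hold all three values.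

Compound 4, `Nc1nc(SCc2ccccc2)c2ncn(/C=C3/CC3(CO)CO)c2n1`, differs from compound 3 by phenyl in place of pentyl on a saturated chain carbon bound to a sulfur. Among the compounds with values here, no measured step exchanges a phenyl for a pentyl here, so nothing predicts a direction for this change; the three limits give the only anchor. Compound 4 is therefore expected to stay at the limit, with an estimated step of a number no higher from compound 3 to compound 4 (the limit leaves the size open) from compound 3. The estimate for compound 4 in this assay is 20000 nM, in the range 7000 nM to 50000 nM.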

Compound 4, half-maximal cytotoxic concentration: > 20000 nM
Compound 4: only a limit was reported; the forecaster's own chance of this, stated with the estimate: 70%; the middle value sits exactly at the limit.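

Within the data shown here, compound 4 gives > 20000 nM in this assay, a limit of the assay and not a number, so no step to compound 4 from compound 1, compound 2 or compound 3 can be read. On these data alone, whether propylamino, propoxy, hexylsulfanyl and benzylsulfanyl differ at all on this read-out remains open.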